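The source may report more compounds than this note shows. Statements on the series, on what has been measured and on what is new or still open speak of the compounds shown alone.

The measured compounds:

Compound 1 `CCCCCCn1cc(COc2ccc(C(=O)/C=C/c3ccccc3)c(O)c2)nn1` – in an ADME assay on cells (Macrophage) for cytotoxicity, read by resazurin assay, with a stated time of 48 h (a higher number here means that more compound is tolerated, a lower number that less compound is tolerated), compound 1 gives "not determined" (no result reported).
Compound 2 `O=C(/C=C/c1ccccc1)c1ccc(OCc2cn(Cc3ccccc3)nn2)cc1O` – in this assay compound 2 gives 80000 nM.

Compound 1 carries a hexyl chain on its triazole; compound 2 carries a benzyl group there instead. For compound 1 no number is available in this assay, so it cannot be placed on any scale. For the measured compounds named here, for compound 2 the reading is the only measured value, and no step between measured compounds is known. Compound 3 `CCCCCCn1cc(COc2ccc(C(=O)/C=C/c3c(F)cccc3Cl)c(O)c2)nn1` has not been measured yet.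

From compound 1 to compound 3 the change is 2-chloro-6-fluorophenyl in place of phenyl on a double-bonded chain carbon bound to a double-bonded chain carbon. This is a small change at the far end of the unsaturated chain, away from the triazole and the hexyl group. Going by the values given here, with no measured step at hand, no direction can be read from the data. The expectation is that the step from compound 1 to compound 3 in this assay stays within the usual scatter, or at most modestly lowers the tolerated concentration. Compound 3 is expected to give about 50000 nM, estimated between 15000 nM and 150000 nM.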

Compound 3, half-maximal cytotoxic concentration: > 100000 nM
Compound 3: no number, only a limit; the forecaster's own chance of this, stated with the estimate: 30%; middle value at least 2.0-fold (0.30 log units) from the limit.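

In this assay, for the compounds shown here, compound 1 has no number, and no step from compound 1 to compound 3 can be read. Compound 3 gives > 100000 nM as a limit of the assay, not a number. The compounds shown leave open whether 2-chloro-6-fluorophenyl in place of phenyl changes the concentration that the cells tolerate.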